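A few compounds are considered here, and "the series" means these few. Any claim that something is new, unique, unknown or untested is made for them only; others in the source may bear on it.

Going by the values given here, in an ADME assay on BCBL1 cells (Homo sapiens) for cytotoxicity, with a stated time of 7 days (on this read-out higher numbers stand for lower toxicity in this test and lower numbers for higher toxicity in this test), compound 1 `CNc1nc(N)nc2c1ncn2/C=C1/CC1(CO)CO` gives 67000 nM and is the only member of the series with a true number so far. Compound 2 `C=CCOc1nc(N)nc2c1ncn2/C=C1/CC1(CO)CO` gives > 20000 nM as a limit of the assay and not a number. Compound 3 `CCCSc1nc(N)nc2c1ncn2/C=C1/CC1(CO)CO` gives > 20000 nM as a limit too, so its place on the scale is not fixed. The evidence on the measured steps comes down to the limit of > 20000 nM in this assay, at which 2 of the 3 values shown sit, and little else.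

The next change leads to compound 4 `Nc1nc(N2CCCC2)c2ncn(/C=C3/CC3(CO)CO)c2n1` with pyrrolidin-1-yl in place of propylsulfanyl on an aromatic carbon and puts pyrrolidin-1-yl in place of propylsulfanyl on an aromatic carbon. The measured steps that bear on it are a step that the limit leaves unreadable from compound 1 to compound 3 and a step that the two limits leave unreadable from compound 2 to compound 3 and neither has a size that can be carried over. No step beyond the usual scatter can therefore be expected in either direction in this assay on this evidence. Among the compounds with values here, the expectation leans on compound 1 at 67000 nM as the one number available. Compound 4 may again return only a limit. The expected change is a step that the limit leaves unreadable from compound 3 to compound 4 and remains an estimate only. For compound 4 the estimated value is 40000 nM with an expected range from 15000 nM to 100000 nM.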

Compound 4, half-maximal cytotoxic concentration: > 20000 nM
Compound 4: no number, only a limit (the forecaster's own chance of this, stated with the estimate: 55%); the middle value lies beyond the limit too.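

Compound 4 gives > 20000 nM in this assay, a limit and not a number, so no new step can be read between it and compound 1, compound 2 or compound 3. Left open is how compound 2, compound 3 and compound 4 rank against compound 1 and each other, with the series resting on one boundary: the limit of > 20000 nM in this assay, at which 3 of the 4 values shown sit.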